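This account rests on a few compounds, and the source may have more. Where it says the series, first, only, none or still open, it means among the compounds named here.

In an ADME assay on the whole organism (Mus musculus, strain CD-1) for pharmacokinetics, at a dose of 10 mg/kg by the oral route (on this read-out lower numbers stand for lower exposure and higher numbers for higher exposure at the dose given), compound 2 (`COc1cc([C@](O)(CCN(C)C)[C@@H](c2cc3cc(Br)ccc3nc2OC)c2ccnc(OC)c2OC)cc(OC(C)C)n1`) gives 5600 ng.h/mL, compound 1 (`COc1cc([C@](O)(CCN(C)C)[C@@H](c2cc3cc(Br)ccc3nc2OC)c2cccc(OC)c2F)cc(OC(C)C)n1`) gives 9000 ng.h/mL and compound 3 (`CCOc1cc([C@](O)(CCN(C)C)[C@@H](c2cc3cc(Br)ccc3nc2OC)c2ccnc(OC)c2OC)cc(OC(C)C)n1`) gives 32000 ng.h/mL. Compound 2 therefore stands within the scatter of compound 1 and clearly under compound 3. Compound 4 (`COc1nc2ccc(Br)cc2cc1[C@@H](c1ccnc(OC)c1OC)[C@@](O)(CCN(C)C)c1cc(SC)nc(SC)c1`) differs from compound 2 as follows: a group of 10 heavy atoms (7 carbon, 1 nitrogen, 2 sulfur; one six-membered aromatic ring with 1 hetero atom) in place of a group of 12 heavy atoms (9 carbon, 1 nitrogen, 2 oxygen; one six-membered aromatic ring with 1 hetero atom), on a saturated chain carbon bound to an oxygen on a saturated carbon and two saturated chain carbons. The closest evidence is a 5.7-fold higher number from compound 2 to compound 3 (0.76 log units; beyond the scatter), a change inside the group that leaves. The other measured step, a 1.6-fold lower number from compound 1 to compound 2 (0.21 log units; within the scatter), lies elsewhere in the molecule. Within the data shown here, no measured step introduces the group that enters, so only a small rise in this assay is expected, with wide uncertainty. The expected change is a 1.4-fold higher number from compound 2 to compound 4 (0.15 log units; within the scatter). Compound 4 is estimated at 8000 ng.h/mL, within an expected range of 2500 ng.h/mL to 30000 ng.h/mL.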

Compound 4, area under the concentration-time curve: 3900 ng.h/mL
Compound 4: the middle estimate sits 2.1-fold (0.31 log units) above what was measured, and the stated range covers the measured number.
By their numbers in this assay, from the lowest: compounds 4, 2 and 1 (each within the scatter of the next, the first and the last beyond it); then compound 3.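

In this assay, replacing the whole group of 12 heavy atoms with the group of 10 heavy atoms containing 2 sulfur atoms gives a 1.4-fold lower number from compound 2 to compound 4 (0.16 log units; within the scatter), so this position tolerates this exchange without a change beyond the scatter. Among these compounds, until now, the only measured change at this group lay inside it, namely a 5.7-fold higher number from compound 2 to compound 3 (0.76 log units; beyond the scatter). No measurement shown here accounts for the result. As far as these compounds go, it remains open whether a ring carrying an amine or a carboxylic acid at this place would stay within the scatter of compound 2.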